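Dichlorophenyl to dimethoxyphenyl on the carbonyl of compound 1

The source may hold more compounds than are shown below. What is called first, only, known or untested is meant among the compounds shown, and "the series" means these compounds.

Compound 1 `COc1cc(-c2cc(/C=C/C(=O)c3ccc(Cl)c(Cl)c3)[nH]n2)cc(OC)c1OC` gives -32% in a functional assay on HCT-116 cells (Homo sapiens) for cytotoxicity, read by sulforhodamine B assay, with a stated time of 48 h, tested at 100 uM (on this read-out lower numbers stand for a stronger effect and higher numbers for a weaker effect at the one concentration tested), the highest of the two numbers at hand. Compound 2 `COc1ccc(-c2cc(/C=C/C(=O)c3ccc(N)cc3)[nH]n2)cc1OC` gives -89% in this assay, a number well beyond the scatter below it. Compound 3 `COc1ccc(C(=O)/C=C/c2cc(-c3cc(OC)c(OC)c(OC)c3)n[nH]2)cc1OC` differs from compound 1 in one place: 3,4-dimethoxyphenyl in place of 3,4-dichlorophenyl on a carbonyl carbon. For the measured compounds named here, no measured pair shows this change, so the step is expected only in loose terms, toward a lower number, with a size of a number 18 percentage points lower from compound 1 to compound 3 (beyond the scatter). Compound 3 is estimated at -50%, with a range from -85% to -10%.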

Compound 3, a percentage reported as activity, at one concentration (the size of the read-out at that concentration, not a potency): -13%
Estimate against measurement, compound 3: 37 percentage points below; measured number inside the range.
By their numbers in this assay, from the lowest: compound 2; then compound 1; then compound 3.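

On a carbonyl carbon, 3,4-dimethoxyphenyl in place of 3,4-dichlorophenyl moves the read-out in this assay by a number 19 percentage points higher from compound 1 to compound 3 (beyond the scatter) and so gives the weaker effect at the one concentration tested. This first single-place step shows that the group at this position matters to the size of the effect. Nothing at hand accounts for the direction of this step.

As far as these compounds go, how a plain phenyl or a phenyl bearing a carboxylic acid would read on this carbonyl carbon remains open. So does whether this change would give a similar step with other parts of compound 1 altered.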